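A few compounds are considered here, and "the series" means these few. Any claim that something is new, unique, unknown or untested is made for them only; others in the source may bear on it.

In an assay for inhibition of Pro-cathepsin H (Homo sapiens), read by fluorescence, tested at 50 uM (a higher number here means more inhibition at the concentration tested (going by the name of the read-out), a lower number less inhibition), compound 2 `CCSc1nc(SCc2ccccc2)nc(=O)[nH]1` gives -4.06%. Compound 3 `O=C(O)CSc1nc(SCc2ccccc2)nc(=O)[nH]1` differs from it in one place, and compound 3 gives 6.89%. For the measured compounds named here, that step, a number 11 percentage points higher from compound 2 to compound 3 (beyond the scatter), is the only measured change in this set. Compound 1 `N#Cc1cccc(CSc2nc(SCc3ccccc3)nc(=O)[nH]2)c1` belongs to the same series, but in this assay compound 1 gives "not determined" (no result reported), so among the two numbers shown compound 3 stands highest, with compound 2 the nearest and lower by a step beyond the scatter.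

Compound 4 `O=c1nc(SCc2ccccc2)nc(SCC2CCCC2)[nH]1` is the next member to be measured. Its difference from compound 3 is cyclopentyl in place of carboxy on a saturated chain carbon bound to a sulfur. Going by the values given here, the one step that bears on it, from compound 2 to compound 3, put carboxy in place of methyl on a saturated chain carbon bound to a sulfur and gave a modest rise. Compound 4 instead takes the carboxy away again and puts a five-membered ring of carbon only in its place, so that on that saturated chain carbon compound 4 is closer to compound 2 than to compound 3. Compound 4 is therefore expected to give back part of that gain or stay roughly level, a step of a number 6.9 percentage points lower from compound 3 to compound 4 (within the scatter) within the scatter. Compound 4 is estimated at 0%, with a range from -12% to 12%.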

Compound 4, a percentage reported as inhibition, at one concentration (the size of the read-out at that concentration, not a potency): 10.6%
Compound 4: middle estimate off by 10.6 percentage points, on the low side, within the range that was stated.
By their numbers in this assay, from the lowest: compound 2; then compounds 3 and 4 (each within the scatter of the next).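

In this assay, cyclopentyl in place of carboxy on a saturated chain carbon bound to a sulfur gives a number 3.7 percentage points higher from compound 3 to compound 4 (within the scatter), so this assay does not separate these two groups, even though one is an open group with a hydrogen-bond donor and acceptor and the other is a ring of carbon only with neither. Against methyl in the same place, cyclopentyl gives a number 14.7 percentage points higher from compound 2 to compound 4 (beyond the scatter), a modest step, and so the earlier gain over compound 2 no longer belongs to carboxy alone: two very different groups at this position both stand beyond the scatter from compound 2. No measurement on hand says what lies behind this shared gain over compound 2.

The compounds shown leave open whether the gain over compound 2 depends on the size of the group at this position, as a longer chain or a cyclohexyl ring in the same place could show. They also leave open whether an amine there would stay level with compound 3 and compound 4 or fall back towards compound 2.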